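This account rests on a few compounds, and the source may have more. Where it says the series, first, only, none or still open, it means among the compounds named here.

Compound 1, `COc1ccccc1C(=O)NCc1ccc(CNS(=O)(=O)c2cccc(C)c2)cc1`, and compound 2, `COc1ccccc1C(=O)NCc1ccc(CNS(=O)(=O)c2cccc(F)c2)cc1`, share one core and differ only in the group on the sulfonyl sulfur. In an assay on MDA-MB-231 cells for displacement of a labelled ligand from C-X-C chemokine receptor type 4 (Homo sapiens), read by fluorescence and microscopy, with stated times of 10 min and 30 min (a lower number here means that less compound is needed, a higher number that more compound is needed for the effect), compound 1 gives 1000 nM, and compound 2 gives 1000 nM, so compound 2 stands level with compound 1; the step of no change at the digits printed from compound 1 to compound 2 (within the scatter). Compound 3, `COc1ccccc1C(=O)NCc1ccc(CNS(=O)(=O)c2ccc(Cl)cc2)cc1`, has not yet been measured. Its difference from compound 2 is 4-chlorophenyl in place of 3-fluorophenyl on a sulfonyl sulfur. Among the measured compounds shown here, the only measured step that bears on this change is no change at the digits printed from compound 1 to compound 2 (within the scatter), which replaced methyl with fluoro on that ring and left the rest of the ring as it was, producing nothing beyond the scatter. The change to compound 3 replaces the whole 3-fluorophenyl by 4-chlorophenyl, so the measured step covers it only in part. For the measured compounds named here, with the single relevant step showing no movement, the expectation for compound 3 in this assay is a step of no change at the digits printed from compound 2 to compound 3 (within the scatter), meaning no change beyond the scatter is expected. Compound 3 is therefore estimated at 1000 nM, with a likely range from 400 nM to 2500 nM.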

Compound 3, effective concentration (reported as EC, without a stated level of effect): 1000 nM
Compound 3: middle estimate and measured number agree at the digits printed, and the stated range covers the measured number.
By their numbers in this assay, from the lowest: compounds 1, 2 and 3 (each within the scatter of the next).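

The earlier step changed only the group on the ring, while the ring position stayed the same. Here, replacing 3-fluorophenyl with 4-chlorophenyl on the sulfonyl sulfur changes both the halogen and its place in the ring at once, and this assay shows no change at the digits printed from compound 2 to compound 3 (within the scatter) as the outcome. Replacing the 3-methylphenyl of compound 1 with the same 4-chlorophenyl gives no change at the digits printed from compound 1 to compound 3 (within the scatter) in that assay, so all three substituted phenyl groups at this position read alike, although the two changes in the step to compound 3 cannot be separated, and no measurement here offers an explanation for this flat result.

On these data alone, all three compounds keep a phenyl ring with one small substituent on the sulfonyl sulfur, so it remains open how this assay would respond to a carboxylic acid or an amine on that ring, or to a longer alkyl chain in place of the ring. The rest of the shared core is identical in compound 1, compound 2 and compound 3, so these results say nothing about changes made there.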